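Urotensin-2 receptor series: para-methyl ester analogue, compound 4

This account rests on a few compounds, and the source may have more. Where it says the series, first, only, none or still open, it means among the compounds named here.

Measured so far:
- compound 1 `COc1ccc(C(=O)OC(CCN(C)C)c2ccc(Cl)cc2)cc1`, 84%
- compound 2 `CN(C)CCC(OC(=O)c1ccc(C(F)(F)F)cc1)c1ccc(Cl)cc1`, 47%
- compound 3 `Cc1cccc(C(=O)OC(CCN(C)C)c2ccc(Cl)cc2)c1C`, 91%

In an assay on NIH3T3 cells with Urotensin-2 receptor (Homo sapiens) as the target (a higher number here means a larger maximal response, a lower number a smaller maximal response), compound 1 stands second highest of the three numbers. Its nearest neighbour is compound 3, a number 7 percentage points higher from compound 1 to compound 3 (within the scatter). Its furthest is compound 2, a number 37 percentage points lower from compound 1 to compound 2 (beyond the scatter).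

Compound 4 `Cc1ccc(C(=O)OC(CCN(C)C)c2ccc(Cl)cc2)cc1` is not yet measured. It differs from compound 1 in one place: methyl in place of methoxy on an aromatic carbon.

Two measured steps start from compound 1 and change the same aryl ester portion. The step to compound 2 is large and downward; the step to compound 3, which also replaces the methoxy-bearing ring with a methyl-bearing one, is within the scatter. Among the compounds with values here, neither is the same change as that to compound 4, and no measured pair shows methyl in place of methoxy directly. Within the data shown here, since the closest precedent, compound 3 with 91%, gives a step within the scatter, the expected step in this assay for compound 4 is a number 1 percentage points higher from compound 1 to compound 4 (within the scatter), that is, none beyond the scatter. The estimate for compound 4 is 85%, range 65% to 100%.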

Compound 4, largest response reached (reported as efficacy), in percent of the reference or control that the assay uses: 56%
The estimate for compound 4 lay 29 percentage points above the measured number; measured number below the stated range.
By their numbers in this assay, from the lowest: compounds 2 and 4 (each within the scatter of the next); then compounds 1 and 3 (each within the scatter of the next).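

In this assay, the aromatic carbon para to a large group proves sensitive to the exchange of methoxy for methyl (a number 28 percentage points lower from compound 1 to compound 4 (beyond the scatter)), which the step from compound 1 to compound 3, with its different ring pattern, gave no sign of. Methyl in place of trifluoromethyl (a number 9 percentage points higher from compound 2 to compound 4 (within the scatter)) leaves compound 4 level with compound 2 within the scatter, so at this position methoxy stands apart from both groups. The change to 4-methylphenyl from 2,3-dimethylphenyl (a number 35 percentage points lower from compound 3 to compound 4 (beyond the scatter)) shows that a methyl-bearing ring alone does not keep the response high; compound 3 goes against any reading that methyl lowers it.

Open, as far as these compounds go, is whether ethoxy, hydroxyl or an amine at this position would keep the response seen with methoxy, and what a single methyl at either of the positions in 2,3-dimethylphenyl would give. No data on the cause of these steps are at hand.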